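The source may report more compounds than this note shows. Statements on the series, on what has been measured and on what is new or still open speak of the compounds shown alone.

In an ADME assay on MT4 cells (Homo sapiens) for cytotoxicity (a higher number here means that more compound is tolerated, a lower number that less compound is tolerated), compound 3 `FC(F)(F)c1cccc(NC(=S)Nc2ccc(I)cc2)c1` gives 10000 nM, the second highest of the three numbers shown. Compound 2 `FC(F)(F)c1cccc(NC(=S)Nc2ccc(Cl)cc2)c1` gives 6800 nM, and a 1.5-fold higher number from compound 2 to compound 3 (0.17 log units; within the scatter). Compound 1 `Fc1ccccc1NC(=S)Nc1cccc(C(F)(F)F)c1` gives 47000 nM, and a 4.7-fold lower number from compound 1 to compound 3 (0.67 log units; beyond the scatter). Compound 4 `FC(F)(F)c1cccc(NC(=S)NCc2ccco2)c1` differs from compound 3 in one place: (furan-2-yl)methyl in place of 4-iodophenyl on an amide-type nitrogen. Going by the values given here, the steps that bear on this change are the two on the same nitrogen, together with the halogen swap within the scatter; one of them is the modest move already given from compound 1 to compound 3, the other is a 6.9-fold lower number from compound 1 to compound 2 (0.84 log units; beyond the scatter). Among the compounds with values here, no measured step exchanges an aryl group on that nitrogen for a (furan-2-yl)methyl group, so the direction is uncertain. A modest step toward a higher number is expected, a 1.8-fold higher number from compound 3 to compound 4 (0.26 log units; within the scatter). Compound 4 is therefore estimated at 18000 nM, within 6000 nM to 55000 nM.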

Compound 4, half-maximal cytotoxic concentration: 43000 nM
Estimate against measurement, compound 4: 2.4-fold (0.38 log units) below; the range from low to high includes it.
By their numbers in this assay, from the lowest: compounds 2 and 3 (each within the scatter of the next); then compounds 4 and 1 (each within the scatter of the next).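

In this assay, (furan-2-yl)methyl on the amide-type nitrogen gives a 4.3-fold higher number from compound 3 to compound 4 (0.63 log units; beyond the scatter) and a 6.3-fold higher number from compound 2 to compound 4 (0.80 log units; beyond the scatter) when it enters in place of 4-iodophenyl and 4-chlorophenyl. Set against 2-fluorophenyl, the same group gives a 1.1-fold lower number from compound 1 to compound 4 (0.04 log units; within the scatter) and stays within the scatter. This position therefore holds a group with a methyl link and a five-membered ring at the level of compound 1, and only the two 4-halophenyl compounds stand apart. Nothing measured here accounts for these steps. As far as these compounds go, whether a plain alkyl chain or an amine on this nitrogen would stay at that level remains open.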